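The source may hold more compounds than are shown below. What is called first, only, known or untested is meant among the compounds shown, and "the series" means these compounds.

Going by the values given here, compound 2, with the structure `Oc1ccc(-c2cc(-c3ccccc3)nc(-c3ccccc3Cl)c2)cc1`, is the only member of this small set with a number attached: in a functional assay on DU-145 cells (Homo sapiens) for cytotoxicity, read by CCK-8 assay and cell counting, with a stated time of 2 days (on this read-out higher numbers stand for weaker inhibition and lower numbers for stronger inhibition), compound 2 gives 2800 nM. It therefore stands alone as the single reference point, since the related compound 1, with the structure `Oc1ccc(-c2cc(-c3cccnc3)nc(-c3ccccc3Cl)c2)cc1`, has "not determined" (no result reported) in this assay. Compound 3, with the structure `Oc1ccc(-c2cc(-c3cccs3)nc(-c3ccccc3Cl)c2)cc1`, shares the core of compound 2 and differs from it in one place: thiophen-2-yl in place of phenyl on an aromatic carbon. Among the compounds with values here, no step between two measured compounds is available here, so there is nothing to show how such a swap of groups has moved the read-out. A thiophen-2-yl standing in for a phenyl is a modest change in size and shape, and the expected step in this assay from compound 2 to compound 3 is a 1.1-fold lower number from compound 2 to compound 3 (0.05 log units; within the scatter), that is, no shift beyond the ordinary scatter in either direction. On that basis compound 3 is estimated to give 2500 nM in this assay, with a range from 900 nM to 7000 nM around that estimate.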

Compound 3, half-maximal inhibitory concentration: 4190 nM
Beside the measured number, compound 3's estimate is 1.7-fold (0.22 log units) below it, within the range that was stated.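

In this assay, going by these compounds alone, placing thiophen-2-yl instead of phenyl on the aromatic carbon next to the ring nitrogen gives a 1.5-fold higher number from compound 2 to compound 3 (0.18 log units; within the scatter), which provides the first measured step at this position. The two compounds therefore cannot be told apart on this read-out: a five-membered aromatic ring with a sulfur atom and a six-membered aromatic ring of carbon only give results within the ordinary scatter, with the 2-chlorophenyl and 4-hydroxyphenyl groups left unchanged. No measurement is available that bears on why these two groups read alike, and this single step does not establish a rule for other aromatic rings.

Going by these compounds, compound 1 gives "not determined" (no result reported), so any step involving compound 1 cannot be read, and the effect of its nitrogen-containing ring at this position remains unknown. The compounds shown also leave open whether a non-aromatic group at this carbon, such as an amine, a carboxylic acid or a longer carbon chain, would move the number in this assay beyond the scatter, and in which direction.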